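Replacing (tert-butyl)sulfonyl with methyl: compound 3 to compound 4

A few compounds are considered here, and "the series" means these few. Any claim that something is new, unique, unknown or untested is made for them only; others in the source may bear on it.

Measured in a functional assay on NCI-H460 cells (Homo sapiens) for cytotoxicity, read by MTT assay, with a stated time of 72 h; a higher number here means a weaker inhibitor, a lower number a stronger inhibitor:
compound 1 `O=c1[nH]/c(=C\c2nc[nH]c2C2CC2)c(=O)[nH]/c1=C\c1cccc(Oc2ccc(F)cc2)c1`: 15.2 nM
compound 2 `O=c1[nH]/c(=C\c2ccc(Br)o2)c(=O)[nH]/c1=C\c1cccc(Oc2ccc(F)cc2)c1`: 361 nM
compound 3 `CC(C)(C)S(=O)(=O)OCc1ccc(/C=c2\[nH]c(=O)/c(=C/c3cccc(Oc4ccc(F)cc4)c3)[nH]c2=O)o1`: 378 nM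

Compound 3 at 378 nM and compound 2 at 361 nM sit together within the scatter at the upper end of the three numbers, while compound 1 at 15.2 nM lies far lower.

The next structure is compound 4 `COCc1ccc(/C=c2\[nH]c(=O)/c(=C/c3cccc(Oc4ccc(F)cc4)c3)[nH]c2=O)o1`. The change from compound 3 is methyl in place of (tert-butyl)sulfonyl on an oxygen on a saturated carbon, so that (((tert-butyl)sulfonyl)oxy)methyl becomes methoxymethyl.

For the measured compounds named here, two measured steps bear on this. The closer one, bromo to (((tert-butyl)sulfonyl)oxy)methyl on an aromatic carbon, is a 1.0-fold higher number from compound 2 to compound 3 (0.02 log units; within the scatter). It shows no change beyond the scatter at the carbon that carries the group now being altered. The other, a 24-fold higher number from compound 1 to compound 2 (1.38 log units; beyond the scatter), is large, but it exchanges the whole 5-cyclopropyl-1H-imidazol-4-yl group and sets no size for the present edit. Going by the values given here, no measured step alters the group on this oxygen directly, so the evidence is thin.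

No step beyond the scatter is expected in this assay, and no direction is favoured. The estimated step is a 1.2-fold lower number from compound 3 to compound 4 (0.07 log units; within the scatter). Compound 4 is expected at 320 nM, with an estimated range of 110 nM to 900 nM.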

Compound 4, half-maximal inhibitory concentration: 14 nM
For compound 4 the middle estimate is 23-fold (1.36 log units) above the measured one; measured number below the stated range.
By their numbers in this assay, from the lowest: compounds 4 and 1 (each within the scatter of the next); then compounds 2 and 3 (each within the scatter of the next).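

Working notes on the series: in this assay, the group on the oxygen on a saturated carbon has a large effect, with methyl in place of (tert-butyl)sulfonyl giving a large step (a 27-fold lower number from compound 3 to compound 4 (1.43 log units; beyond the scatter)), whereas the earlier exchange of bromo for (((tert-butyl)sulfonyl)oxy)methyl stayed within the scatter. Methoxymethyl in place of bromo on the aromatic carbon also gives a large step (a 26-fold lower number from compound 2 to compound 4 (1.41 log units; beyond the scatter)), so this aromatic carbon is not indifferent to what it carries, as compounds 2 and 3 alone suggested. With 5-(methoxymethyl)furan-2-yl in place of 5-cyclopropyl-1H-imidazol-4-yl, the step lies within the scatter (a 1.1-fold lower number from compound 1 to compound 4 (0.04 log units; within the scatter)), so the large loss seen for compound 2 against compound 1 does not extend to every furan-bearing compound here.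

The data shown offer no measured basis for explaining any of these steps. Still open, going by these compounds, is whether a hydroxymethyl, an aminomethyl or a longer ether chain such as ethoxymethyl in place of methoxymethyl would group with compound 4 or with compound 3 in this assay.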